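The compounds below may be only part of what the source reports. "The series", "measured", "known", "first", "only" and "open" are said of these compounds alone.

Measured so far in a toxicity assay on MDCK cells (Canis lupus familiaris) for cytotoxicity, read by CCK-8 assay, with a stated time of 48 h; a lower number here means that less compound is tolerated, a higher number that more compound is tolerated:
compound 1 `CCCOc1ccc(C(=O)NNc2c(Br)cccc2Br)cc1`: > 100000 nM
compound 2 `CC(C)(C)c1ccc(C(=O)NNc2c(Br)cccc2Br)cc1`: > 100000 nM
compound 3 `O=C(NNc1c(Br)cccc1Br)c1ccc(F)cc1`: > 100000 nM

Compound 3 stands at > 100000 nM, which is a limit and not a number. The series as a whole offers no number either, as the limit of > 100000 nM in this assay, at which 3 of the 3 values shown sit, shows, so compound 3 cannot be ranked against the others.

The next structure is compound 4 `O=C(NNc1c(Br)cccc1Br)c1ccc(-c2ccccc2)cc1`, reached by phenyl in place of fluoro on an aromatic carbon. Phenyl thus takes the place of fluoro on an aromatic carbon, para to a large group.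

The measured exchanges on an aromatic carbon are the ones that bear on this change: a step that the two limits leave unreadable from compound 2 to compound 3, a step that the two limits leave unreadable from compound 1 to compound 3 and a step that the two limits leave unreadable from compound 1 to compound 2. None of them has a readable size. The closest comparison for the incoming group is compound 2, which carries tert-butyl. Compound 2 gives > 100000 nM, again a limit.

Among the compounds with values here, with a step that the two limits leave unreadable from compound 2 to compound 3 as the only guide for a change between fluoro and a larger group, no step beyond the scatter is expected in this assay, and no direction can be drawn. The expected outcome is a number no higher from compound 3 to compound 4 (the limit leaves the size open). The most likely report is another limit. For compound 4 the estimated value is 100000 nM, with an expected range from 50000 nM to 150000 nM.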

Compound 4, half-maximal cytotoxic concentration: 84100 nM
Beside the measured number, compound 4's estimate is 1.2-fold (0.08 log units) above it; low and high end bracket the measured number.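

In this assay compound 4 gives 84100 nM as a measured number, so phenyl on this aromatic carbon, para to a large group, is the one exchange shown that brings the read-out inside the tested range. On these data alone, the change reads as an at least 1.1-fold lower number from compound 3 to compound 4 (0.07 log units; that floor lies within the scatter) and as an at least 1.1-fold lower number from compound 2 to compound 4 (0.07 log units; that floor lies within the scatter) and as an at least 1.1-fold lower number from compound 1 to compound 4 (0.07 log units; that floor lies within the scatter) and each of these floors lies within the scatter, so a real fall in tolerated concentration is not established and the true size of all three steps stays open. The steps among compound 1, compound 2 and compound 3 still cannot be read, and compound 4 remains the only point in the series with a number: the limit of > 100000 nM in this assay, at which 3 of the 4 values shown sit.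

As far as these compounds go, whether an amine, a carboxylic acid or a longer alkoxy chain on this aromatic carbon would also give a number or would stay at the limit remains open. Also open, from the compounds shown here alone, is whether the number of compound 4 depends on the second aromatic ring itself, which a cyclohexyl group or a benzyl group in the same place could help to separate.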